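A few compounds are considered here, and "the series" means these few. Any claim that something is new, unique, unknown or untested is made for them only; others in the source may bear on it.

In a functional assay on HeLa cells (Homo sapiens) for antiproliferative activity, read by MTT assay, with a stated time of 48 h (on this read-out higher numbers stand for weaker inhibition and lower numbers for stronger inhibition), three close analogues have been measured. Compound 1 `COc1ccc(/C=C/C(=O)Nc2cc3c(Nc4ccc(Cl)c(Cl)c4)ncnc3s2)cc1` gives 33 nM, compound 2 `COc1ccc(/C=C/C(=O)Nc2cc3c(Nc4cc(Cl)cc(Cl)c4)ncnc3s2)cc1` gives 43300 nM, and compound 3 `O=C(/C=C/c1ccccc1)Nc1cc2ncnc(Nc3cc(Cl)cc(Cl)c3)c2s1` gives 3210 nM. Compound 2 and compound 1 differ in one place only, (3,4-dichlorophenyl in place of 3,5-dichlorophenyl on a nitrogen on an aromatic ring), and that single change gave a 1300-fold lower number from compound 2 to compound 1 (3.12 log units; beyond the scatter). How the core of compound 3 differs from that of compound 2 is not broken down here; their two numbers show compound 3 well under compound 2 and well over compound 1.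

Compound 4 `O=C(/C=C/c1ccccc1)Nc1cc2ncnc(Nc3ccc(Cl)c(Cl)c3)c2s1` is still to be measured in this assay. It stands to compound 3 as compound 1 stands to compound 2: 3,4-dichlorophenyl in place of 3,5-dichlorophenyl on a nitrogen on an aromatic ring. The place described for both pairs reads the same word for word, so this is the same change, not merely the same kind. For the measured compounds named here, a large drop from compound 3 is therefore expected, because the only precedent is a 1300-fold lower number from compound 2 to compound 1 (3.12 log units; beyond the scatter), although with just one earlier example the size is uncertain and may not carry over in full. The step from compound 3 to compound 4 is expected to be a 210-fold lower number from compound 3 to compound 4 (2.33 log units; beyond the scatter). Compound 4 is accordingly estimated at 15 nM, most plausibly between 2 nM and 150 nM.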

Compound 4, half-maximal inhibitory concentration: 10700 nM
Beside the measured number, compound 4's estimate is 710-fold (2.85 log units) below it, outside the stated range (above it).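

In this assay, replacing 3,5-dichlorophenyl with 3,4-dichlorophenyl gave a 3.3-fold higher number from compound 3 to compound 4 (0.52 log units; beyond the scatter), a modest rise where the earlier pair had shown a very large fall. The change therefore did not carry from one core to the other in this series, in either direction or size: the same change on two cores in this assay, a 1300-fold lower number (3.12 log units; beyond the scatter) from compound 2 to compound 1 and a 3.3-fold higher number (0.52 log units; beyond the scatter) from compound 3 to compound 4, 4400-fold (3.64 log units) apart, beyond the scatter of two such steps. For the compounds shown here, with only two pairs, this shows that the outcome of the change differs between these two settings, but it does not show which structural difference between them is responsible, since compound 2 and compound 3 differ in more than one place.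

The compounds shown leave open whether the methoxy group of compound 1 and compound 2 or the arrangement of the core decides the outcome of the change. They also leave open how either core would respond if the dichlorophenyl group were replaced by a fluorophenyl or bromophenyl group, or if the cinnamoyl phenyl ring carried a dimethylamino group.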